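Series notes: chloro to bromo on the aromatic ring

The compounds below may be only part of what the source reports. "The series", "measured", "known", "first", "only" and "open" are said of these compounds alone.

Measured compounds:
compound 1 `NC1=NC2(CCOCC2)N(OCCCOc2ccc(Cl)c(Cl)c2)C(N)=N1` — 590 nM
compound 2 `NC1=NC2(CCOCC2)N(OCCCOc2ccc(F)cc2)C(N)=N1` — "not determined" (no result reported)
compound 3 `NC1=NC2(CCOCC2)N(OCCCOc2ccccc2Cl)C(N)=N1` — 1430 nM

In a functional assay on MDA-MB-231 cells (Homo sapiens) for antiproliferative activity, read by MTT assay, with a stated time of 72 h (a higher number here means a weaker inhibitor, a lower number a stronger inhibitor), compound 3 gives the higher of the two numbers available, with compound 1 beyond the scatter below it; compound 2 has no result. Among the measured compounds shown here, the single step between measured compounds, a 2.4-fold higher number from compound 1 to compound 3 (0.38 log units; beyond the scatter), is the only reference point. Compound 4 `NC1=NC2(CCOCC2)N(OCCCOc2ccccc2Br)C(N)=N1` differs from compound 3 by bromo in place of chloro on an aromatic carbon. For the measured compounds named here, no measured pair exchanges one halogen for another, so that step bears only loosely on the present change: it altered which halogens sit on the ring and how many, not their kind. Compound 4 is therefore expected to show a step of a 1.1-fold lower number from compound 3 to compound 4 (0.04 log units; within the scatter), none beyond the scatter. Compound 4 is estimated at 1300 nM, within 600 nM to 2800 nM.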

Compound 4, half-maximal inhibitory concentration: 910 nM
Compound 4: middle estimate off by 1.4-fold (0.15 log units), on the high side; measured number inside the range.
By their numbers in this assay, from the lowest: compounds 1, 4 and 3 (each within the scatter of the next, the first and the last beyond it).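

In this assay, among the compounds shown here, the step of a 1.6-fold lower number from compound 3 to compound 4 (0.20 log units; within the scatter) is the first direct halogen exchange, and it does not separate bromo from chloro on this aromatic carbon, ortho to a large group. The step of a 1.5-fold higher number from compound 1 to compound 4 (0.19 log units; within the scatter) also leaves the 2-bromophenyl and 3,4-dichlorophenyl variants unseparated, so a single halogen on the ring is not set clearly apart from two in every case. No available evidence bears on the reason for either step.

From the compounds shown here alone, whether iodo, methoxy or an amine on this same carbon would give a step beyond the scatter stays open. So does the effect of a longer chain in place of the propyl linker.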